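Swapping Nitro for Bromo on a Triazene Core

The source may hold more compounds than are shown below. What is called first, only, known or untested is meant among the compounds shown, and "the series" means these compounds.

Three triazenes have been run through an ADME assay on MT4 cells (Homo sapiens) for cytotoxicity, read by MTT assay, with a stated time of 96 h; a higher number here means that more compound is tolerated, a lower number that less compound is tolerated. Compound 1 `O=[N+]([O-])c1ccc(/N=N/N2CCCC2)cc1` gives >= 100000 nM in this assay, which is a limit of the assay rather than a number, as the limit of >= 100000 nM in this assay, at which 1 of the 3 values shown sits, records. Compound 2 `CN(C)CCCNc1ccc(/N=N/c2ccccc2)cc1` gives 17000 nM in this assay, and compound 3 `CCOC(=O)N1CCN(/N=N/c2ccccc2)CC1` gives 100000 nM. Compound 1 thus stands at the upper boundary of what the assay can report, with compound 2 the only one of the three showing a clearly lower value.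

Compound 4 `Brc1ccc(/N=N/N2CCCC2)cc1` has not been measured yet. It differs from compound 1 by a single change: bromo in place of nitro on an aromatic carbon. Within the data shown here, no measured pair shows what this swap does, so the expectation rests on compound 1 alone. In this assay a small step toward less compound tolerated is expected, not beyond the usual scatter. Compound 4 is therefore estimated at 70000 nM, with a range from 25000 nM to 150000 nM. The expected step of an at least 1.4-fold lower number from compound 1 to compound 4 (0.15 log units; that floor lies within the scatter) is modest.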

Compound 4, half-maximal cytotoxic concentration: > 100000 nM
Compound 4: a limit, no number; the forecaster's own chance of this, stated with the estimate: 45%; middle value at least 1.4-fold (0.15 log units) away from the limit.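

The step from compound 1 to compound 4 cannot be read, because both results in this assay are limits, not numbers: the limit of > 100000 nM in this assay, at which 1 of the 4 values shown sits.

From the compounds shown here alone, whether bromo in place of nitro changes how much compound is tolerated remains open.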